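Compound 4: two hydroxyls in place of one fluorine

The compounds below may be only part of what the source reports. "The series", "measured", "known", "first", "only" and "open" are said of these compounds alone.

Of the compounds shown here, three sharing one core have been measured in a functional assay on MCF7 cells (Homo sapiens) for cytotoxicity, read by MTT assay, with a stated time of 48 h; a higher number here means a weaker inhibitor, a lower number a stronger inhibitor. Compound 1 `O=C(CSc1nnc(-c2ccncc2)o1)N/N=C/c1cccc(F)c1` gives 24900 nM, compound 2 `O=C(CSc1nnc(-c2ccncc2)o1)N/N=C/c1cccc(C(F)(F)F)c1` gives 14600 nM, and compound 3 `O=C(CSc1nnc(-c2ccncc2)o1)N/N=C/c1ccccc1F` gives 21800 nM. Going by the values given here, compound 3 thus holds the second highest of the three numbers, but all three lie close together: a 1.1-fold lower number from compound 1 to compound 3 (0.06 log units; within the scatter) and a 1.7-fold lower number from compound 1 to compound 2 (0.23 log units; within the scatter), so no compound is set apart from another beyond the scatter. Compound 4 `O=C(CSc1nnc(-c2ccncc2)o1)N/N=C/c1ccc(O)c(O)c1` differs from compound 3 in a single place: 3,4-dihydroxyphenyl in place of 2-fluorophenyl on a carbon with a double bond to nitrogen. Neither measured step bears directly on this change; one moved a fluorine around the phenyl and the other put a trifluoromethyl in its place, and both stayed within the scatter. Among the compounds with values here, no analogue carrying a hydroxyl has been measured, so the range for compound 4 is kept wide. Compound 4 is expected to give 18000 nM in this assay, between 5000 nM and 60000 nM. The expected step is a 1.2-fold lower number from compound 3 to compound 4 (0.08 log units; within the scatter), which would remain within the scatter.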

Compound 4, half-maximal inhibitory concentration: 910 nM
Estimate against measurement, compound 4: 20-fold (1.30 log units) above; measured number outside the range, below it.
By their numbers in this assay, from the lowest: compound 4; then compounds 2, 3 and 1 (each within the scatter of the next).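

In this assay, the group on the carbon with a double bond to nitrogen proves able to shift the number well beyond the scatter, which the fluorine and trifluoromethyl changes had not shown: 3,4-dihydroxyphenyl brings a 24-fold lower number from compound 3 to compound 4 (1.38 log units; beyond the scatter) and a 27-fold lower number from compound 1 to compound 4 (1.44 log units; beyond the scatter). Unlike the 2-fluorophenyl it replaces, which has 0 hydrogen-bond donors and 0 hydrogen-bond acceptors, this group has 2 of each, so the large step comes with the first hydroxyl groups in the series. Nothing available gives a reason for this step.

The two hydroxyls enter together, so the compounds shown leave open whether a single hydroxyl would be enough. They also leave open whether methoxy groups or an amine in their place would give a similar number.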